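The source may report more compounds than this note shows. Statements on the series, on what has been measured and on what is new or still open speak of the compounds shown alone.

Measured so far:
Compound 1, `CCOC(=O)C1=C(C)NC(COC(C)=O)=C(C(=O)OCC)C1c1cccc([N+](=O)[O-])c1`: 37 nM
Compound 2, `C#CCCOC(=O)C1=C(C)NC(C)=C(C(=O)OC)C1c1cccc([N+](=O)[O-])c1`: 35 nM
Compound 3, `CCOC(=O)C1=C(C)NC(C)=C(C(=O)OCCOC)C1c1cccc([N+](=O)[O-])c1`: 82 nM

All three share one core and were tested in a functional assay on HEK293 cells for antagonist activity at Voltage-dependent L-type calcium channel subunit alpha-1D (Rattus norvegicus), read by FLIPR; a higher number here means a weaker inhibitor, a lower number a stronger inhibitor. In this assay compound 2 gives 35 nM, the lowest of the three numbers, but compound 1 lies within the usual scatter of it, so no order can be drawn between those two. Compound 3 gives a number that stands beyond the scatter, higher than that of compound 2, so of that pair compound 3 is the weaker inhibitor.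

Compound 4, `COC(=O)C1=C(C)NC(C)=C(C(=O)OCc2ccc(F)c(F)c2)C1c1cccc([N+](=O)[O-])c1`, has not yet been measured. It differs from compound 2 in one place: 3,4-difluorophenyl in place of propargyl on a saturated chain carbon bound to an oxygen next to a carbonyl group. The propargyl group leaves, and a 3,4-difluorophenyl group enters on the saturated chain carbon bound to an oxygen next to a carbonyl group, so the whole ester side chain changes from (but-3-yn-1-yl)oxy to (3,4-difluorobenzyl)oxy.

Within the data shown here, no step between measured compounds can serve as a guide, since compounds 1, 2 and 3 differ from one another in more than one place. The expectation therefore rests on the measured range alone: the step from compound 2 to compound 4 is expected to be modest, a 1.8-fold lower number from compound 2 to compound 4 (0.24 log units; within the scatter), close to the scatter and, if anything, toward a lower number. Compound 4 is estimated at 20 nM in this assay, with a range from 5 nM to 80 nM.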

Compound 4, half-maximal inhibitory concentration: 20 nM
Estimate against measurement, compound 4: no gap at the digits printed; measured number inside the range.
By their numbers in this assay, from the lowest: compounds 4, 2 and 1 (each within the scatter of the next); then compound 3.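

Among these compounds, this is the first comparison in the set between compounds that differ in only one place, so it is the first direct look at this position. In this assay, the step is a 1.8-fold lower number from compound 2 to compound 4 (0.24 log units; within the scatter), so exchanging propargyl for 3,4-difluorophenyl on a saturated chain carbon bound to an oxygen next to a carbonyl group gives no change that can be told from scatter. A larger group carrying an aromatic ring can therefore stand in place of one with a triple bond without a measurable loss of inhibition in this assay, although no measurement shown explains why the two compounds read alike.

The compounds shown leave open whether the two fluorines contribute anything, as a plain phenyl group at this place is not among them. From the compounds shown here alone, it also remains open whether this single pair speaks for groups of a different kind, such as an amine or a carboxylic acid at the end of a longer chain, at the same place.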